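Adding a Trifluoromethyl Group to a Weak Inhibitor

A few compounds are considered here, and "the series" means these few. Any claim that something is new, unique, unknown or untested is made for them only; others in the source may bear on it.

Compound 1 `O=C(Nc1cccc(-n2cc(-c3ccncc3)c(-c3ccc(Cl)c(O)c3)n2)c1)Nc1cccc(C(F)(F)F)c1` was tested in a functional assay on SK-MEL-28 cells (Homo sapiens) for inhibition, read by sulforhodamine B assay, with a stated time of 48 h; on this read-out lower numbers stand for stronger inhibition of growth and higher numbers for weaker inhibition of growth. In this assay compound 1 gives only a limit, > 32500 nM, and not a number, so its position on the scale is known only as a boundary. Compound 2 `O=C(Nc1cccc(-n2cc(-c3ccncc3)c(-c3ccc(Cl)c(O)c3)n2)c1)Nc1ccc(Cl)c(Cl)c1` differs from it by carrying 3,4-dichlorophenyl in place of 3-(trifluoromethyl)phenyl on an amide-type nitrogen, and in this assay compound 2 gives 9850 nM; the change brings an at least 3.2-fold lower number from compound 1 to compound 2 (0.51 log units; beyond the scatter).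

Compound 3 `O=C(Nc1cccc(-n2cc(-c3ccncc3)c(-c3ccc(Cl)c(O)c3)n2)c1)Nc1cc(C(F)(F)F)cc(C(F)(F)F)c1` is reached from compound 1 by a different change: trifluoromethyl in place of hydrogen on an aromatic carbon. Within the data shown here, no measured step mirrors this change; the one measured step shows only that altering the substituents on this ring can move the number at least modestly. Starting from a limit, the direction for compound 3 is uncertain, and compound 3 is expected to stay weak, at 20000 nM with a range from 6000 nM to 60000 nM, which would mean an estimated at least 1.6-fold lower number from compound 1 to compound 3 (0.21 log units; that floor lies within the scatter).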

Compound 3, concentration for total growth inhibition: 1570 nM
Beside the measured number, compound 3's estimate is 13-fold (1.11 log units) above it; measured number outside the range, below it.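

In this assay, this aromatic carbon, meta to a trifluoromethyl group, turns out to be a place where one added group matters: a second trifluoromethyl here gives an at least 20-fold lower number from compound 1 to compound 3 (1.31 log units; beyond the scatter), while the first trifluoromethyl stays where it was. The earlier step swapped the substituents on this ring, whereas this one only adds to them, and it turns a compound without a measured number into one with a measured number. The printed size is only a floor because compound 1 is known only as a limit: the limit of > 32500 nM in this assay, at which 1 of the 3 values shown sits.

Going by these compounds, whether a nitrile, a methoxy group or an amine on this same carbon would also lower the number remains open. So does whether a single trifluoromethyl at this carbon, without the first one, would be enough.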